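Fluoro on the phenylsulfanyl ring of compound 3

This account rests on a few compounds, and the source may have more. Where it says the series, first, only, none or still open, it means among the compounds named here.

Measured in a functional assay on the whole organism with Mus musculus as the target (a higher number here means that more compound is needed for the effect, a lower number that less compound is needed), so far
- compound 1 `Cc1c(C)c2c(c(C)c1N)CC(C)(C)O2` gives 7.8 mg/kg as a number
- compound 2 `Cc1c(N)c(C)c2c(c1CN(C)C)OC(C)(C)C2` gives > 50 mg/kg as a limit of the assay
- compound 3 `Cc1c(C)c2c(c(C)c1N)CC(C)(CSc1ccccc1)O2` gives 24.7 mg/kg as a number

Compound 3 stands with 24.7 mg/kg as the higher of the two true numbers, and compound 1 stands with 7.8 mg/kg as the lower one. The entry for compound 2 is only a limit.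

Compound 4 `Cc1c(C)c2c(c(C)c1N)CC(C)(CSc1ccc(F)cc1)O2` differs from compound 3 by one change, fluoro in place of hydrogen on an aromatic carbon which reads as fluoro in place of hydrogen on an aromatic carbon, or phenyl to 4-fluorophenyl.

The measured steps bear on this only indirectly. The phenylsulfanyl group that now carries the change came with a 3.2-fold higher number from compound 1 to compound 3 (0.50 log units; beyond the scatter) as a step at another place on the core. The other measured step, an at least 6.4-fold higher number from compound 1 to compound 2 (0.80 log units; beyond the scatter) in this assay, rests on a limit and also lies elsewhere. Neither replaces a hydrogen on an aromatic carbon, so neither sets the size of this one. No step beyond the scatter is expected, and the estimated step is a 1.3-fold lower number from compound 3 to compound 4 (0.11 log units; within the scatter) in this series. For compound 4 the expected value is 19 mg/kg with an estimated range from 8 mg/kg to 45 mg/kg in this assay for now.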

Compound 4, dose for 50% inhibition: 17.9 mg/kg
The estimate for compound 4 lay 1.1-fold (0.03 log units) above the measured number, within the range that was stated.
By their numbers in this assay, from the lowest: compound 1; then compounds 4 and 3 (each within the scatter of the next). At a limit, above all of these: compound 2.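

In this assay, within the data shown here, fluoro in place of hydrogen on an aromatic carbon, para to a large group, gives a 1.4-fold lower number from compound 3 to compound 4 (0.14 log units; within the scatter) and so no step that can be told from repeated measurement. Among these compounds, the earlier steps lay elsewhere on the shared core, which makes this the only reading on the ring of the phenylsulfanyl group itself: this position accepts a fluoro with compound 3 and compound 4 remaining within the scatter of each other. Nothing among the data shown bears on why this change gives so small a step.

Going by these compounds, whether an amine or a carboxylic acid at this same place on the ring would give a step beyond the scatter stays open, as does the effect of a longer chain in place of the phenylsulfanyl group. Among the compounds shown here, with only the pair of compound 3 and compound 4 on this ring, no trend can be drawn for other groups or for other places on it.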